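The source may report more compounds than this note shows. Statements on the series, on what has been measured and on what is new or still open speak of the compounds shown alone.

Measured so far:
compound 1, `CO/N=C/C=C/c1ccccc1OC(=O)c1ccccc1`, > 100000 nM
compound 2, `CC(=O)ONC(=O)/C=C/c1ccccc1OC(=O)c1ccccc1`, 16800 nM

In a functional assay on SK-OV-3 cells (Homo sapiens) for inhibition, read by ELISA, with a stated time of 24 h (on this read-out lower numbers stand for stronger inhibition of growth and higher numbers for weaker inhibition of growth), compound 1 reaches only a limit of the assay, > 100000 nM. Compound 2 gives 16800 nM in this assay, the single number shown. The step of an at least 5.9-fold lower number from compound 1 to compound 2 (0.77 log units; beyond the scatter) rests on that limit, (the limit of > 100000 nM in this assay, at which 1 of the 2 values shown sits), so its true size is open.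

Compound 3, `CN1CCN(C(=O)/C=C/c2ccccc2OC(=O)c2ccccc2)CC1`, is the next member. Against compound 2 the change is 4-methylpiperazin-1-yl in place of acetoxyamino on a carbonyl carbon. Within the data shown here, the one measured step also altered the group on the chain carbon side of the core, yet it swapped a different pair of groups, so it bears on the new step only loosely and fixes neither its direction nor its size. The expected step in this assay, a 1.1-fold lower number from compound 2 to compound 3 (0.05 log units; within the scatter), is therefore taken as small, with wide uncertainty. Compound 3 is estimated at 15000 nM, between 3000 nM and 80000 nM.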

Compound 3, concentration for 50% growth inhibition: > 100000 nM
Compound 3 ended at the assay's limit; the forecaster's own chance of this, stated with the estimate: 25%; middle value at least 6.6-fold (0.82 log units) away from the limit.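

The group on the carbonyl carbon has a clear effect in this assay: 4-methylpiperazin-1-yl in place of acetoxyamino gives an at least 5.9-fold higher number from compound 2 to compound 3 (0.77 log units; beyond the scatter), so this position does not accept every amide-forming group equally. Compound 3 gives only a limit, > 100000 nM, which is not a number. Among the compounds shown, acetoxyamino is the only group that yields a measured value, and the full size of the loss on leaving it cannot be read because the step rests on a limit: the limit of > 100000 nM in this assay, at which 2 of the 3 values shown sit.

On these data alone, it remains open whether a hydroxyamino group or a small open-chain amine such as dimethylamino on the same carbonyl carbon would give a measured value. As far as these compounds go, it is also open whether the ring of 4-methylpiperazin-1-yl or the removal of acetoxyamino accounts for the change.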